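A few compounds are considered here, and "the series" means these few. Any claim that something is new, unique, unknown or untested is made for them only; others in the source may bear on it.

Compound 1 `CCN(c1nc(Cl)nc(N[C@@H](C)c2ccccc2)n1)C(C)C` gives 229 nM in an ADME assay on the whole organism for inhibition, with Echinochloa crus-galli var. formosensis as the target, with a stated time of 4 days (on this read-out lower numbers stand for stronger inhibition and higher numbers for weaker inhibition), and stands lowest of the two numbers in hand; compound 2 `CC(C)N(c1nc(Cl)nc(N[C@H](C)c2ccccc2)n1)C(C)C` gives 6610 nM in this assay, a gap beyond the scatter. Compound 3 `CCC(CC)Nc1nc(Cl)nc(N[C@@H](C)c2ccccc2)n1` has not been measured. It differs from compound 1 in one place: (pentan-3-yl)amino in place of ethyl(isopropyl)amino on an aromatic carbon. Among the compounds with values here, no pair of measured compounds separated by a single change exists in this set, so the step must be judged from the two values alone. The expected step of a 1.0-fold lower number from compound 1 to compound 3 (0.02 log units; within the scatter) is none beyond the scatter, since nothing in hand points either way. Compound 3 is expected to give 220 nM, within a range of 60 nM to 800 nM.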

Compound 3, half-maximal inhibitory concentration: 23400 nM
The estimate for compound 3 lay 110-fold (2.03 log units) below the measured number; the whole stated range lies below it.
By their numbers in this assay, from the lowest: compound 1; then compound 2; then compound 3.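

In this assay, (pentan-3-yl)amino in place of ethyl(isopropyl)amino on the aromatic carbon gives a 100-fold higher number from compound 1 to compound 3 (2.01 log units; beyond the scatter), although the two groups hold the same heavy atoms. The position therefore separates two groups of equal atom count, which differ in chain arrangement and in the hydrogen-bond donor present only in the entering group. No available measurement bears on what underlies this step. Still open, from the compounds shown here alone, is whether a methyl group on the nitrogen of (pentan-3-yl)amino would return the value towards that of compound 1, which would separate the donor from the chain arrangement.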